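Thiosemicarbazone series: nitro step from compound 3 to compound 4

The source may report more compounds than this note shows. Statements on the series, on what has been measured and on what is new or still open speak of the compounds shown alone.

The series shares one core. Compound 1 `CC1=CC[C@H](C(C)(C)NC(=S)N/N=C/c2ccc(N(C)C)cc2)CC1` carries a dimethylamino group on the aromatic ring; compound 2 `CC1=CC[C@H](C(C)(C)NC(=S)N/N=C/c2ccc(Cl)cc2)CC1` carries a chloro group there. In a functional assay on UACC-62 cells (Homo sapiens) for inhibition, read by sulforhodamine B assay, with a stated time of 48 h (a higher number here means a weaker inhibitor of growth, a lower number a stronger inhibitor of growth), compound 1 gives only a limit, > 100000 nM. In this assay compound 2 likewise gives only a limit, > 100000 nM. The step that the two limits leave unreadable from compound 1 to compound 2 therefore cannot be sized. Compound 3 `CC1=CC[C@H](C(C)(C)NC(=S)N/N=C(\C)c2ccccc2)CC1` carries neither group on the aromatic ring. In this assay compound 3 also gives only a limit, > 100000 nM. All three values sit at the limit of > 100000 nM in this assay, at which 3 of the 3 values shown sit, so compound 3 stands level with the others as far as the numbers reach, with no order among them.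

Compound 4 `CC1=CC[C@H](C(C)(C)NC(=S)N/N=C(\C)c2ccc([N+](=O)[O-])cc2)CC1` differs from compound 3 by nitro in place of hydrogen on an aromatic carbon. Going by the values given here, no measured step bears on it: the only step, from the dimethylamino to the chloro, is unreadable, and no pair tests a nitro group. Compound 3 sits at the limit > 100000 nM, as do its neighbours. Compound 4 is therefore expected to stay at the limit too, a step that the limit leaves unreadable from compound 3 to compound 4 of no size beyond the scatter. The estimate for compound 4 in this assay is 150000 nM, between 50000 nM and 500000 nM.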

Compound 4, concentration for total growth inhibition: 46800 nM
Compound 4: the middle estimate sits 3.2-fold (0.51 log units) above what was measured; measured number outside the range, below it.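

In this assay, going by these compounds alone, nitro on an aromatic carbon, para to a large group, is the first change with a readable direction: an at least 2.1-fold lower number from compound 3 to compound 4 (0.32 log units; beyond the scatter). Compound 4 is the only compound shown that carries a measured number and not a limit: the limit of > 100000 nM in this assay, at which 3 of the 4 values shown sit. Compound 3 holds only a limit, so this step gives a minimum size with no upper end, and the aromatic ring emerges as a site where a single substitution can bring a compound of this series into the measurable range.

The compounds shown leave open whether the lower number belongs to nitro itself or would also come with another group in the same place, such as a nitrile, a carboxylic acid or a primary amine on the core of compound 3. They also leave open whether nitro would produce a similar step on the core of compound 1, which has a hydrogen in place of the methyl group on the carbon of the carbon-nitrogen double bond, and whether a longer chain at that carbon would change the reading.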